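The source may hold more compounds than are shown below. What is called first, only, known or untested is meant among the compounds shown, and "the series" means these compounds.

Three amides sharing one core were compared in an assay on isolated protein for displacement of a labelled ligand from D(4) dopamine receptor (Homo sapiens); a lower number here means a stronger inhibitor, a higher number a weaker inhibitor. Compound 1 `O=C(NC1CCN(Cc2cccc(Cl)c2)CC1)c1cccc2ccccc12` gives 116 nM. Compound 2 `O=C(NC1CCN(Cc2ccc(Cl)cc2)CC1)c1cccc2ccccc12` gives 43 nM. Compound 3 `O=C(NC1CCN(Cc2ccc(C(F)(F)F)cc2)CC1)c1cccc2ccccc12` gives 96 nM, the second highest of the three numbers; its gap to compound 1 lies within the scatter, whereas a 2.2-fold higher number from compound 2 to compound 3 (0.35 log units; beyond the scatter) lies beyond it. Compound 4 `Cc1cccc(CN2CCC(NC(=O)c3cccc4ccccc34)CC2)c1` differs from compound 3 by 3-methylphenyl in place of 4-(trifluoromethyl)phenyl on a saturated chain carbon bound to an amine nitrogen in a ring. Among the measured compounds shown here, two measured steps bear on this: a 1.2-fold lower number from compound 1 to compound 3 (0.08 log units; within the scatter) hardly moved the number, and a 2.7-fold lower number from compound 1 to compound 2 (0.43 log units; beyond the scatter) was only modest. The change to 3-methylphenyl is therefore expected to bring little movement, a 1.3-fold higher number from compound 3 to compound 4 (0.10 log units; within the scatter). Compound 4 is thus estimated at 120 nM, with a likely range from 55 nM to 260 nM.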

Compound 4, inhibition constant: 77 nM
Compound 4: the middle estimate sits 1.6-fold (0.19 log units) above what was measured, and the stated range covers the measured number.
By their numbers in this assay, from the lowest: compounds 2, 4, 3 and 1 (each within the scatter of the next, the first and the last beyond it).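

Putting methyl in place of chloro on the aromatic carbon gives a 1.5-fold lower number from compound 1 to compound 4 (0.18 log units; within the scatter), so in this assay this exchange does not move the number beyond the scatter. Compound 4 is also separated from neither of the other two, with a 1.2-fold lower number from compound 3 to compound 4 (0.10 log units; within the scatter) and a 1.8-fold higher number from compound 2 to compound 4 (0.25 log units; within the scatter), whereas compound 1 and compound 3 each stand beyond the scatter from compound 2. No measurement here offers an explanation for these results. As far as these compounds go, the result for 4-methylphenyl remains open, as does the effect of a methoxy group or an amine on this phenyl ring.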